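A few compounds are considered here, and "the series" means these few. Any claim that something is new, unique, unknown or untested is made for them only; others in the source may bear on it.

Measured compounds:
- compound 1 `Cc1cccc(C)c1OC[C@H](N)c1ccccc1` — 3020 nM
- compound 2 `Cc1cccc(C)c1OC[C@@H](N)c1ccccc1` — 3020 nM
- compound 3 `Cc1cc(Cl)cc(C)c1OC[C@@H](C)CN` — 2880 nM

In an assay on isolated protein for inhibition of sodium channel protein type 4 subunit alpha (Homo sapiens) (a lower number here means that less compound is needed, a higher number that more compound is needed for the effect), compound 1 gives 3020 nM and compound 2 gives 3020 nM; the step of no change at the digits printed from compound 1 to compound 2 (within the scatter) is within the scatter, consistent with the fact that compounds 1 and 2 differ only in the configuration as drawn. In this assay compound 3 gives 2880 nM, the lowest of the three numbers, but its gaps to compound 1 and compound 2 are both within the scatter, so the three values are not separated.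

Compound 4 `Cc1cccc(C)c1OC[C@@H](C)CN` is not yet measured. It differs from compound 3 in one place: hydrogen in place of chloro on an aromatic carbon. For the measured compounds named here, none of the measured steps concerns a chloro group; the only measured step, from compound 1 to compound 2, is a change of configuration and gives no guide to a substituent removal at the aromatic ring. The expectation therefore rests on compound 3 alone and on the small size of the change.

For compound 4 in this assay a step of a 1.4-fold higher number from compound 3 to compound 4 (0.14 log units; within the scatter) is expected, likely within or only slightly beyond the scatter. The estimate for compound 4 in this assay is 4000 nM, with a range from 1300 nM to 12000 nM.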

Compound 4, half-maximal effective concentration: 17400 nM
For compound 4 the middle estimate is 4.4-fold (0.64 log units) below the measured one; measured number outside the range, above it.
By their numbers in this assay, from the lowest: compounds 3, 1 and 2 (each within the scatter of the next); then compound 4.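

In this assay, for the compounds shown here, the aromatic carbon meta to two methyl groups and para to a group of 6 heavy atoms responds to its substituent: hydrogen in place of chloro gives a 6.0-fold higher number from compound 3 to compound 4 (0.78 log units; beyond the scatter), the only step beyond the scatter. The numbers of compounds 1, 2 and 3 lie within the scatter of one another and gave no sign that this carbon matters, whereas here the loss of a single chlorine atom separates two compounds. Nothing available bears on why this step has its size.

Still open, as far as these compounds go, is whether the step belongs to chloro itself or would also appear with fluoro, bromo, methyl or trifluoromethyl on this carbon. Also open, from the compounds shown here alone, is whether a chloro group on the core of compound 1 would give a step of similar size.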